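The compounds below may be only part of what the source reports. "The series", "measured", "known", "first", "only" and "open" are said of these compounds alone.

Measured in a functional assay on HT-29 cells (Homo sapiens) for inhibition, read by MTT assay, with a stated time of 72 h; on this read-out higher numbers stand for weaker inhibition and lower numbers for stronger inhibition:
- compound 1 `CC(=O)Oc1cc(C(=O)C2=C(O)[C@]3(CC=C(C)C)C[C@@H](C/C=C(\C)CCC=C(C)C)[C@](C)(CCC=C(C)C)[C@](CC=C(C)C)(C2=O)C3=O)ccc1O`: 10200 nM
- compound 2 `CC(=O)Oc1ccc(C(=O)C2=C(O)[C@]3(CC=C(C)C)C[C@@H](C/C=C(\C)CCC=C(C)C)[C@](C)(CCC=C(C)C)[C@](CC=C(C)C)(C2=O)C3=O)cc1OC(C)=O`: 12200 nM

Only these two numbers exist so far, and they cannot be told apart. Going by the values given here, compound 1 stands level with its sole neighbour, the one measured step being a 1.2-fold higher number from compound 1 to compound 2 (0.08 log units; within the scatter). Compound 3 `CC(C)=CCC/C(C)=C/C[C@@H]1C[C@]2(CC=C(C)C)C(=O)[C@@](CC=C(C)C)(C(=O)C(C(=O)c3ccc(O)c(OC(=O)CCCC[C@@H]4SCC5NC(=O)NC54)c3)=C2O)[C@@]1(C)CCC=C(C)C` keeps the core of compound 1 and differs from it by a group of 12 heavy atoms (8 carbon, 2 nitrogen, 1 oxygen, 1 sulfur; one five-membered non-aromatic ring with 1 hetero atom, one five-membered non-aromatic ring with 2 hetero atoms) in place of a hydrogen atom, on a saturated chain carbon bound to a carbonyl carbon. The measured step bears on this only in part, as it concerns an acetyl in place of hydrogen on an oxygen on an aromatic ring, a far smaller change. Among the compounds with values here, no measured compound carries the entering group, so the data give no direct size for it. Within the data shown here, with a 1.2-fold higher number from compound 1 to compound 2 (0.08 log units; within the scatter) as the only guide, a small rise in the number is expected in this assay, perhaps nothing beyond the scatter. The expected change is a 1.4-fold higher number from compound 1 to compound 3 (0.14 log units; within the scatter). The estimate for compound 3 is 14000 nM, with an expected range from 6000 nM to 35000 nM.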

Compound 3, half-maximal inhibitory concentration: 18200 nM
For compound 3 the middle estimate is 1.3-fold (0.11 log units) below the measured one; the range from low to high includes it.
By their numbers in this assay, from the lowest: compounds 1, 2 and 3 (each within the scatter of the next).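

In this assay, a group of 12 heavy atoms with two five-membered non-aromatic rings, in place of a hydrogen atom on a saturated chain carbon bound to a carbonyl carbon, gives a 1.8-fold higher number from compound 1 to compound 3 (0.25 log units; within the scatter) and no readable change. The earlier pair covered only an acetyl in place of hydrogen on an oxygen on an aromatic ring, whereas this far larger group also stays within the scatter of compound 1. No measurement at hand offers an explanation for this result.

On these data alone, it remains open whether a carboxylic acid, an amine or a longer chain at this place would read differently. It is also open whether either five-membered ring matters on its own, since the compounds shown include no change that clearly moves the number.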